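The source may hold more compounds than are shown below. What is called first, only, known or untested is meant among the compounds shown, and "the series" means these compounds.

Measured compounds:
Compound 1, `NC1=NS(=O)(=O)c2ccccc21`: 7.39 10^-6 cm/s
Compound 2, `CCN=S1(=O)NC(=O)c2ccccc21`: 26.8 10^-6 cm/s

Both compounds were run in an ADME assay on Caco-2 cells (Homo sapiens) for permeability; on this read-out higher numbers stand for higher permeability and lower numbers for lower permeability. Compound 1 stands at the lowest of the two numbers; compound 2 gives the higher number, and the gap between them is beyond the usual scatter of this assay. The two structures differ in more than one place, so that gap cannot be traced to a single change.

Compound 3, `CCNC1=NS(=O)(=O)c2ccccc21`, has not yet been measured in this assay. It differs from compound 1 in one place: ethyl in place of hydrogen on an amine nitrogen. Among the compounds with values here, no measured pair shows this change, so its size is uncertain. In this assay the expected step is a 1.9-fold higher number from compound 1 to compound 3 (0.28 log units; within the scatter), a rise that would lie beyond the scatter. For compound 3 the estimated value is 14 10^-6 cm/s, with a range from 7 10^-6 cm/s to 28 10^-6 cm/s.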

Compound 3, apparent permeability in the Caco-2 assay: 29.3 10^-6 cm/s
Estimate against measurement, compound 3: 2.1-fold (0.32 log units) below, and the stated range ends below it.
By their numbers in the Caco-2 assay, from the lowest: compound 1; then compounds 2 and 3 (each within the scatter of the next).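

Within the data shown here, in the Caco-2 assay ethyl in place of hydrogen on an amine nitrogen gives a 4.0-fold higher number from compound 1 to compound 3 (0.60 log units; beyond the scatter) and is the first change in one place seen here, so this nitrogen is a place where a small chain can move the read-out beyond the scatter. In a physicochemical assay for solubility (on this read-out higher numbers stand for higher solubility and lower numbers for lower solubility), compound 1 gives 798000 nM and compound 3 gives 971000 nM with a step of a 1.2-fold higher number from compound 1 to compound 3 (0.09 log units; within the scatter) and so, on this read-out, the same change does not separate the two. Nothing shown here explains either step.

Methyl, or a longer chain such as propyl or butyl, on the same nitrogen would show whether the number keeps rising, levels off or falls with chain length. On these data alone, this change rests on a single pair, so whether ethyl does the same on another core remains open.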